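Methyl to Methoxy on the Sulfonyl-Bearing Ring

A few compounds are considered here, and "the series" means these few. Any claim that something is new, unique, unknown or untested is made for them only; others in the source may bear on it.

Three measured compounds share a core built around a bromobenzyl amine joined through a six-carbon chain to a sulfonamide. Compound 1 `O=S(=O)(NCCCCCCNCc1ccc(Br)cc1)c1ccc(C(F)(F)F)cc1` carries a trifluoromethyl on its sulfonyl-bearing ring and in a functional assay on MIA PaCa-2 cells (Homo sapiens) for inhibition, read by MTT assay, with a stated time of 72 h (on this read-out lower numbers stand for stronger inhibition of growth and higher numbers for weaker inhibition of growth), compound 1 gives 3830 nM. Compound 2 `O=S(=O)(NCCCCCCNCc1ccc(Br)cc1)c1ccc2c(c1)OCC2` gives 13000 nM, and compound 3 `Cc1ccc(S(=O)(=O)NCCCCCCNCc2ccc(Br)cc2)cc1` gives 12300 nM. Compound 3 thus stands second highest of the three; its number and that of compound 2 lie within the scatter of each other, whereas the number for compound 1 sits clearly lower.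

Compound 4 `COc1ccc(S(=O)(=O)NCCCCCCNCc2ccc(Br)cc2)cc1` differs from compound 3 by methoxy in place of methyl on an aromatic carbon. Two earlier steps are relevant. One is a change on an aromatic carbon of the same ring: a 3.2-fold higher number from compound 1 to compound 3 (0.51 log units; beyond the scatter). The other replaced the whole group on the sulfonyl sulfur: a 1.1-fold lower number from compound 2 to compound 3 (0.02 log units; within the scatter). Neither involved methoxy, so there is no direct guide; a small exchange of this kind is expected to give a step no larger than the scatter, a 1.1-fold higher number from compound 3 to compound 4 (0.02 log units; within the scatter). Compound 4 is therefore estimated at 13000 nM, within a range from 5000 nM to 32000 nM.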

Compound 4, concentration for 50% growth inhibition: 13000 nM
Estimate against measurement, compound 4: no gap at the digits printed; the measured number falls inside the stated range.
By their numbers in this assay, from the lowest: compound 1; then compounds 3, 2 and 4 (each within the scatter of the next).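

In this assay, the step of a 1.1-fold higher number from compound 3 to compound 4 (0.02 log units; within the scatter) shows that this position, para to a large group, tolerates methoxy in place of methyl with no readable effect, even though methoxy adds an oxygen and a hydrogen-bond acceptor. The larger group on the sulfonyl sulfur of compound 2 also reads the same as 4-methoxyphenyl, with no change at the digits printed from compound 2 to compound 4 (within the scatter) as the step. Trifluoromethyl remains the one group here that stands apart, now against methoxy as well as methyl, with a 3.4-fold higher number from compound 1 to compound 4 (0.53 log units; beyond the scatter) as the step.

Nothing available explains why trifluoromethyl differs from the other two groups. Going by these compounds, it also remains open whether a nitrile, a chlorine or an amine at this position would match compound 1 or compound 4, and whether a shorter chain would alter these steps.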